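Replacing the 2-fluorophenyl group of compound 2

The compounds below may be only part of what the source reports. "The series", "measured", "known", "first", "only" and "open" are said of these compounds alone.

In a functional assay on MDA-MB-231 cells (Homo sapiens) for antiproliferative activity, read by MTT assay, with a stated time of 24 h (a lower number here means a stronger inhibitor, a higher number a weaker inhibitor), compound 1 `O=C(NNc1ccccc1Cl)c1cccc(NS(=O)(=O)c2cnc(O)nc2O)c1` gives 2090 nM. Compound 2 `O=C(NNc1ccccc1F)c1cccc(NS(=O)(=O)c2cnc(O)nc2O)c1` gives > 20000 nM, which is a limit of the assay and not a number. Among the measured compounds shown here, of the two compounds measured so far, it is the one that stands at the limit of > 20000 nM in this assay, at which 1 of the 2 values shown sits.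

Compound 3 `Cc1ccccc1C(=O)NNC(=O)c1cccc(NS(=O)(=O)c2cnc(O)nc2O)c1` keeps the shared core but carries (2-methylphenyl)carbonyl in place of 2-fluorophenyl on an amine nitrogen. For the measured compounds named here, no measured step makes this exchange. Going by the values given here, the only step available is an at least 9.5-fold higher number from compound 1 to compound 2 (0.98 log units; beyond the scatter), with fluoro in place of chloro on an aromatic carbon. It lies beyond the scatter and shows that a single change in this part of the series can move this assay substantially, but it gives no direct measure of the new group.

Since compound 2 has no number, a modest move toward a lower number is expected, and a second limit reading remains quite possible. The expected change is an at least 2.0-fold lower number from compound 2 to compound 3 (0.30 log units; that floor lies within the scatter). Compound 3 is estimated at 10000 nM, with an expected range of 2000 nM to 40000 nM.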

Compound 3, half-maximal inhibitory concentration: 18100 nM
Compound 3: middle estimate off by 1.8-fold (0.26 log units), on the low side, within the range that was stated.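

On this amine nitrogen, (2-methylphenyl)carbonyl in place of 2-chlorophenyl gives an 8.7-fold higher number from compound 1 to compound 3 (0.94 log units; beyond the scatter) in this assay, so a group that brings in a carbonyl and a hydrogen-bond acceptor does not hold the level reached with 2-chlorophenyl, and compound 1 keeps the lowest number of the three, with its steps to both others lying beyond the scatter. Set against 2-fluorophenyl, the same group gives an at least 1.1-fold lower number from compound 2 to compound 3 (0.04 log units; that floor lies within the scatter), and with that floor inside the scatter, the exchange cannot be read as a real gain. The reading for compound 2 remains a limit of the assay and not a number: the limit of > 20000 nM in this assay, at which 1 of the 3 values shown sits.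

Compound 3 brings in the carbonyl and the methyl group together, and the compounds shown do not separate the two, which a 2-methylphenyl group directly on the amine nitrogen or an unsubstituted phenylcarbonyl group could do. They also leave open how far the number depends on the halogen itself, as a bromo or iodo group in place of chloro on the aromatic carbon would show.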